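A few compounds are considered here, and "the series" means these few. Any claim that something is new, unique, unknown or untested is made for them only; others in the source may bear on it.

Measured compounds:
- compound 1, `COc1c(F)c(N)c2c(=O)cc(-c3ccc(N)c(F)c3)oc2c1F`: 34000 nM
- compound 2, `CCOC(=O)c1c(F)c(N)c2c(=O)cc(-c3ccc(N)c(F)c3)oc2c1F`: > 100000 nM

In a functional assay on HeLa cells (Homo sapiens) for cytotoxicity, read by neutral red uptake, with a stated time of 3 days (a higher number here means a weaker inhibitor, a lower number a stronger inhibitor), compound 1 gives 34000 nM. For compound 2 this assay reports only a limit, > 100000 nM, and no number. Compound 2 therefore stands at the weaker end of the two, with the step of an at least 2.9-fold higher number from compound 1 to compound 2 (0.46 log units; beyond the scatter) resting on the limit of > 100000 nM in this assay, at which 1 of the 2 values shown sits, rather than on a measured value.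

Compound 3, `Nc1ccc(-c2cc(=O)c3c(N)c(F)c(C(=O)O)c(F)c3o2)cc1F`, differs from compound 2 in one place: hydrogen in place of ethyl on an oxygen next to a carbonyl group. None of the measured steps concerns this change; the single step shown, an at least 2.9-fold higher number from compound 1 to compound 2 (0.46 log units; beyond the scatter), involves a different group on an aromatic carbon and gives no direction for removing the ethyl. With compound 2 already at a limit, the step from compound 2 to compound 3 is expected to be a number no higher from compound 2 to compound 3 (the limit leaves the size open), that is, no shift beyond the scatter. Compound 3 is thus estimated at 100000 nM, in a range from 30000 nM to 300000 nM, with a fair chance that this assay again reports only a limit.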

Compound 3, half-maximal inhibitory concentration: > 100000 nM
Compound 3 ended at the assay's limit; the forecaster's own chance of this, stated with the estimate: 60%; the middle value lies on the limit itself.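

Carboxy in place of methoxy on this aromatic carbon gives, in this assay, an at least 2.9-fold higher number from compound 1 to compound 3 (0.46 log units; beyond the scatter), so ethoxycarbonyl is no longer the only group here to give a higher number than methoxy, and neither compound goes against this. For compound 3 the assay gives only a limit, > 100000 nM, not a number. The change from ethyl to hydrogen on the oxygen next to the carbonyl group cannot be read, because compound 2 and compound 3 both stop at a limit: the limit of > 100000 nM in this assay, at which 2 of the 3 values shown sit.

On these data alone, the true values of compound 2 and compound 3 remain open, so ethoxycarbonyl and carboxy cannot be ranked. Also open, as far as these compounds go, is whether a primary amide or a nitrile on this aromatic carbon would give a number closer to that of compound 1, 34000 nM.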